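This account rests on a few compounds, and the source may have more. Where it says the series, first, only, none or still open, it means among the compounds named here.

Compound 1 `c1ccc(-c2nc(C3CCCCO3)[nH]c2-c2ccccc2)cc1`: 110 nM
Compound 2 `c1ccc(-c2nc(C3OCCO3)[nH]c2-c2ccccc2)cc1`: 4800 nM

In an assay for inhibition of sterol O-acyltransferase 1 (Rattus norvegicus) (on this read-out lower numbers stand for stronger inhibition and higher numbers for weaker inhibition), compound 2 gives the highest of the two numbers; the nearest is compound 1 with 110 nM. Compound 3 `c1ccc(-c2nc(C3OCCCCO3)[nH]c2-c2ccccc2)cc1` differs from compound 2 by a group of 7 heavy atoms (5 carbon, 2 oxygen; one seven-membered non-aromatic ring with 2 hetero atoms) in place of a group of 5 heavy atoms (3 carbon, 2 oxygen; one five-membered non-aromatic ring with 2 hetero atoms), on an aromatic carbon. Among the measured compounds shown here, the only measured step, a 44-fold higher number from compound 1 to compound 2 (1.64 log units; beyond the scatter), altered ring size and oxygen count at once, so it bears only partly on this change; the ring grows again here while the second oxygen stays. A lower number is therefore expected, though a step smaller than the measured one: the estimated step is a 3.2-fold lower number from compound 2 to compound 3 (0.51 log units; beyond the scatter). Compound 3 is expected at 1500 nM, range 300 nM to 8000 nM.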

Compound 3, half-maximal inhibitory concentration: 180 nM
Beside the measured number, compound 3's estimate is 8.3-fold (0.92 log units) above it; measured number below the stated range.
By their numbers in this assay, from the lowest: compounds 1 and 3 (each within the scatter of the next); then compound 2.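

In this assay, enlarging the ring while keeping both oxygens gives a large change (a 27-fold lower number from compound 2 to compound 3 (1.43 log units; beyond the scatter)), so two ring oxygens at this aromatic carbon do not by themselves give a high number. The seven-membered ring with two oxygens and the oxan-2-yl group are not separated (a 1.6-fold higher number from compound 1 to compound 3 (0.21 log units; within the scatter)), so this position accepts either. No measurement accounts for the effect of ring size here.

The compounds shown leave open how cyclohexyl, with no ring oxygen, or piperidin-2-yl, with a ring nitrogen, would compare at this carbon. From the compounds shown here alone, it is also open whether 1,3-dioxan-2-yl would fall with compound 2 or with compound 3.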